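This account rests on a few compounds, and the source may have more. Where it says the series, first, only, none or still open, it means among the compounds named here.

Two compounds of this series share one core and differ only in the length of the ester chain. Compound 1 `CCCCCOC(=O)CCC(=O)N1CCN(CCCOc2cc3c(Nc4ccc(F)c(Cl)c4)ncnc3cc2OC)CC1` gives 30% in a functional assay on A549 cells (Homo sapiens) for cytotoxicity, read by MTT assay, with a stated time of 24 h, tested at 60 uM; a lower number here means a stronger effect, a higher number a weaker effect of the compound at the concentration tested. For the measured compounds named here, compound 2 `CCCCCCCCCCCOC(=O)CCC(=O)N1CCN(CCCOc2cc3c(Nc4ccc(F)c(Cl)c4)ncnc3cc2OC)CC1` gives 3.9% in this assay and so stands lowest of the two numbers measured so far, its only neighbour being compound 1, whose number is higher by more than the scatter. Going by the values given here, the single measured step, a number 26.1 percentage points lower from compound 1 to compound 2 (beyond the scatter), came from hexyl in place of hydrogen on a saturated chain carbon, five bonds along the chain from an oxygen next to a carbonyl group. Compound 3 `CCCCCCCCCCCCCCCCCCCOC(=O)CCC(=O)N1CCN(CCCOc2cc3c(Nc4ccc(F)c(Cl)c4)ncnc3cc2OC)CC1` has not yet been measured. It differs from compound 2 by octyl in place of hydrogen on a saturated chain carbon, ten or more bonds along the chain from an oxygen next to a carbonyl group. Among the compounds with values here, only the step from compound 1 to compound 2 bears on this change, and it lengthened the same chain in the same manner. Because compound 2 already gives 3.9%, a second fall of that size cannot occur on this scale. The step to compound 3 is therefore expected to be a number 1.9 percentage points lower from compound 2 to compound 3 (within the scatter), within the scatter. Compound 3 is estimated at 2%, most likely between 0% and 9%.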

Compound 3, a percentage reported as activity, at one concentration (the size of the read-out at that concentration, not a potency): 89.3%
Beside the measured number, compound 3's estimate is 87.3 percentage points below it, outside the stated range (above it).
By their numbers in this assay, from the lowest: compound 2; then compound 1; then compound 3.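

With octyl in place of hydrogen on a saturated chain carbon, ten or more bonds along the chain from an oxygen next to a carbonyl group, the read-out in this assay shows a number 85.4 percentage points higher from compound 2 to compound 3 (beyond the scatter) and so runs opposite to the earlier a number 26.1 percentage points lower from compound 1 to compound 2 (beyond the scatter) on the same ester chain. Lengthening this chain therefore does not move the number in one direction across the three compounds: it falls and then rises between compound 1 (30%) and compound 3 (89.3%), so compound 2 is the only one of the three with a low number and the first step alone gave no sign of this turn. No measurement shown here accounts for the reversal.

The compounds shown leave open where between the chains of compound 2 and compound 3 the number turns upward, and whether it climbs gradually or abruptly over that stretch. They also leave open how the read-out would respond if the same chain ended in a carboxylic acid or an amine, or carried a branching methyl group.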